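Working notes: amide nitrogen substituent, compound 3 to compound 4

The source may hold more compounds than are shown below. What is called first, only, known or untested is meant among the compounds shown, and "the series" means these compounds.

Going by the values given here, the series so far holds three measured compounds, all weak. In an assay on isolated protein for inhibition of tyrosine-protein phosphatase non-receptor type 13 (Homo sapiens), read by spectrophotometry (on this read-out lower numbers stand for stronger inhibition and higher numbers for weaker inhibition), compound 1 `Cc1ccc(O)c(C(O)(C(F)(F)F)C(F)(F)F)c1` gives 454000 nM, and compound 2 `Oc1c(-c2ccccc2)cccc1C(O)(C(F)(F)F)C(F)(F)F` gives 449000 nM; the two values sit within the scatter of each other, so no order between them is claimed. Compound 3 `CCCNC(=O)COc1ccc2cc(C(O)(C(F)(F)F)C(F)(F)F)c(O)cc2c1` carries an amide side chain on the shared core. In this assay compound 3 gives no number, only a limit, > 20000 nM. What is known of compound 3 is thus (the limit of > 20000 nM in this assay, at which 1 of the 3 values shown sits), and compound 3 stands on that limit rather than on a value.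

Compound 4 `CC(C)c1ccc(NC(=O)COc2ccc3cc(C(O)(C(F)(F)F)C(F)(F)F)c(O)cc3c2)cc1` is the next member, not yet measured, and differs from compound 3 in one place: 4-isopropylphenyl in place of propyl on an amide-type nitrogen. Among the compounds with values here, no measured pair shows this kind of change, so its direction rests on nothing measured here. The step from compound 3 to compound 4 is expected to be modest, a step that the limit leaves unreadable from compound 3 to compound 4, pointing toward stronger inhibition but not with confidence, since the starting point for compound 3 is itself only a limit. Compound 4 is therefore estimated at 30000 nM in this assay, with a range from 5000 nM to 200000 nM.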

Compound 4, half-maximal inhibitory concentration: 6500 nM
Compound 4: middle estimate off by 4.6-fold (0.66 log units), on the high side; the range from low to high includes it.
By their numbers in this assay, from the lowest: compound 4; then compounds 2 and 1 (each within the scatter of the next).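

Going by these compounds alone, the nitrogen of the amide side chain is the first place where a change can be read: 4-isopropylphenyl in place of propyl gives an at least 3.0-fold lower number from compound 3 to compound 4 (0.48 log units; beyond the scatter) in this assay. Compound 4 also gives the series a number on this amide side chain, so the read-out responds to the substituent on this nitrogen, at least for this one replacement. From the compounds shown here alone, only a lower bound on the size of the step can be given, and its true size stays unknown because the starting point for compound 3 is a limit and not a value: the limit of > 20000 nM in this assay, at which 1 of the 4 values shown sits.

Within the data shown here, the single change brings in an aromatic ring and an isopropyl group together, so the share of each remains unresolved; a plain phenyl on this nitrogen, or a longer chain such as hexyl, would be needed to separate the ring from the added carbon atoms. Going by these compounds, how a carboxylic acid or an amine in place of the isopropyl group on that ring would read in this assay also remains open, so nothing yet says how far this substituent tolerates change.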